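The source may report more compounds than this note shows. Statements on the series, on what has been measured and on what is new or still open speak of the compounds shown alone.

Measured compounds and their values:

Compound 1 `CC(C)N(Cc1cccc(OCCCCCC(=O)O)c1)C(=O)c1ccc(-c2ccc3[nH]ccc3c2)cc1`. In an ADME assay on HepG2 cells (Homo sapiens) for cytotoxicity, read by CellTiter-Glo and resazurin assay, with a stated time of 72 h (a higher number here means that more compound is needed for the effect, a lower number that less compound is needed), compound 1 gives no number but a limit, > 26000 nM.

Compound 2 `CC(C)N(Cc1cccc(OCCCCCC(=O)O)c1)C(=O)c1ccc(-c2ccc3cc[nH]c3c2)cc1`. In this assay compound 2 likewise stops at a limit, > 26000 nM.

Compound 3 `CC(C)N(Cc1cccc(OCCCCCC(=O)O)c1)C(=O)c1ccc(-c2cccc(OC(F)(F)F)c2)cc1`. In this assay compound 3 also ends at a limit, > 26000 nM.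

Compound 3 therefore has no settled place on the numbers shown: its own value is a limit, and the two further values shown are limits as well. All three sit at the limit of > 26000 nM in this assay, at which 3 of the 3 values shown sit, so none of the three compounds can be set apart from the others.

The change to compound 4 `CC(C)N(Cc1cccc(OCCCCCC(=O)O)c1)C(=O)c1ccc(-c2cccc(S(C)(=O)=O)c2)cc1` is methylsulfonyl in place of trifluoromethoxy on an aromatic carbon. Among the measured compounds shown here, two measured steps touch the same part of the molecule, a step that the two limits leave unreadable from compound 1 to compound 3 and a step that the two limits leave unreadable from compound 2 to compound 3, but each runs from one limit to another, and their sizes cannot be read. The data thus give no readable step to lean on, and no direction beyond the scatter can be taken from them.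

The expectation is that compound 4 again reaches the limit in this assay, which as a step means a step that the limit leaves unreadable from compound 3 to compound 4. The estimated value for compound 4 is 40000 nM, with a range from 15000 nM to 150000 nM.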

Compound 4, half-maximal effective concentration: > 26000 nM
Compound 4: a limit, no number; the forecaster's own chance of this, stated with the estimate: 85%; the middle value is on the limit's open side.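

Compound 4 also stops at a limit, so none of the steps to it from compound 1, compound 2 or compound 3 can be read: the limit of > 26000 nM in this assay, at which 4 of the 4 values shown sit.

The compounds shown leave open how far apart these four lie in this assay, and whether any of the exchanged groups changes the concentration needed for the effect.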